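Shortening the Side Chain from Compound 1 to Compound 3

The compounds below may be only part of what the source reports. "The series", "measured", "known", "first", "only" and "open" are said of these compounds alone.

Compound 1 `CCC(C)C1NC(=O)N(C2CCCC2)C1=O` gives > 100 ug/mL in a functional assay on HEL cells (Homo sapiens) for cytotoxicity; a higher number here means that more compound is tolerated, a lower number that less compound is tolerated.
Compound 2 `CCC(C)C(NC(=O)n1nnc2ccccc21)C(=O)NC1CCCCC1` gives 80 ug/mL in this assay.

Compound 1 stands at the limit of > 100 ug/mL in this assay, at which 1 of the 2 values shown sits, so its value is a limit of the assay rather than a measured number. Compound 2 is the one of the two that gives an actual number, and nothing beyond these two values can be said about the pair, since the two compounds differ in more than one place.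

Compound 3 `CC(C)C1NC(=O)N(C2CCCC2)C1=O` has not yet been measured. It differs from compound 1 in one place: hydrogen in place of methyl on a saturated chain carbon, two bonds along the chain from a saturated ring carbon. Going by the values given here, no pair of measured compounds here differs by such a change, so there is no measured step to lean on. A change of this size, with no ring and no donor or acceptor involved, is expected to give a step from compound 1 to compound 3 of about a number no higher from compound 1 to compound 3 (the limit leaves the size open), that is, none beyond the usual scatter in this assay. Compound 3 is therefore expected to give about 100 ug/mL in this assay, within a range from 50 ug/mL to 200 ug/mL, and most likely to be reported again as a limit.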

Compound 3, minimum cytotoxic concentration: > 100 ug/mL
Compound 3 gave a limit, no number; the forecaster's own chance of this, stated with the estimate: 70%; the middle value lies on the limit itself.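

In this assay compound 3 gives > 100 ug/mL, which is a limit and not a number. Compound 1 gives > 100 ug/mL, also a limit, so no step between compound 1 and compound 3 can be read: the limit of > 100 ug/mL in this assay, at which 2 of the 3 values shown sit.

The compounds shown leave open whether going from sec-butyl to isopropyl changes how much compound the cells tolerate.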